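Chloro for Methyl: Expected Exposure of Compound 4

The source may report more compounds than this note shows. Statements on the series, on what has been measured and on what is new or still open speak of the compounds shown alone.

Of the compounds shown here, three sharing one core have been measured in an ADME assay on the whole organism for pharmacokinetics, with Mus musculus as the target, at a dose of 10 mg/kg by the oral route; on this read-out lower numbers stand for lower exposure and higher numbers for higher exposure at the dose given. Compound 1, `CC/C(=C(/c1ccc(/C=C/C(=O)O)cc1)c1ccc2[nH]ncc2c1)c1ccccc1Cl`, gives 15000 ng.h/mL. Compound 2, `CC/C(=C(/c1ccc(/C=C/C(=O)O)cc1)c1ccc2[nH]ncc2c1)c1ccccc1C`, gives 7200 ng.h/mL. Compound 3, `CC/C(=C(/c1ccc(/C=C/C(=O)O)cc1)c1ccc2[nH]ncc2c1)c1ccc(C#N)cc1C`, gives 4300 ng.h/mL.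

Compound 2 and compound 1 differ in one place: chloro in place of methyl on an aromatic carbon. This change gave a 2.1-fold higher number from compound 2 to compound 1 (0.32 log units; beyond the scatter). Compound 3 carries a further group compared with compound 2: cyano in place of hydrogen on an aromatic carbon. That difference gave a 1.7-fold lower number from compound 2 to compound 3 (0.22 log units; within the scatter), so these two values cannot be ordered. Compound 1 and compound 3 are further apart, with a 3.5-fold lower number from compound 1 to compound 3 (0.54 log units; beyond the scatter).

Compound 4, `CC/C(=C(/c1ccc(/C=C/C(=O)O)cc1)c1ccc2[nH]ncc2c1)c1ccc(C#N)cc1Cl`, is not yet measured. It differs from compound 3 in the same way that compound 1 differs from compound 2: chloro in place of methyl on an aromatic carbon. The surroundings are not identical, since in compound 4 the place is ortho to a large group and meta to a cyano group, whereas in compound 1 the place is only ortho to a large group, so this is the same kind of change rather than the same one. Because compound 2 to compound 1 gave a 2.1-fold higher number from compound 2 to compound 1 (0.32 log units; beyond the scatter), a step of similar size is expected here, estimated as a 2.0-fold higher number from compound 3 to compound 4 (0.30 log units; within the scatter) in this assay. Compound 4 is therefore expected to give about 8500 ng.h/mL, plausibly between 3800 ng.h/mL and 19000 ng.h/mL.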

Compound 4, area under the concentration-time curve: 2900 ng.h/mL
Beside the measured number, compound 4's estimate is 2.9-fold (0.47 log units) above it; measured number below the stated range.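

In this assay chloro in place of methyl gives a 1.5-fold lower number from compound 3 to compound 4 (0.17 log units; within the scatter) and so leaves those two values unordered, which means that the gain seen on the core without the cyano group did not carry over to the core with it: the same change on two cores in this assay, a 2.1-fold higher number (0.32 log units; beyond the scatter) from compound 2 to compound 1 and a 1.5-fold lower number (0.17 log units; within the scatter) from compound 3 to compound 4, 3.1-fold (0.49 log units) apart, beyond the scatter of two such steps.

Cyano in place of hydrogen gives a 5.2-fold lower number from compound 1 to compound 4 (0.71 log units; beyond the scatter) when chloro is present, so the size of this change also depends on the core that receives it: the same change on two cores in this assay, a 1.7-fold lower number (0.22 log units; within the scatter) from compound 2 to compound 3 and a 5.2-fold lower number (0.71 log units; beyond the scatter) from compound 1 to compound 4, 3.1-fold (0.49 log units) apart, beyond the scatter of two such steps.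

Taken together, the two changes give a 2.5-fold lower number from compound 2 to compound 4 (0.39 log units; beyond the scatter) and show that, in these four compounds, their effects do not simply add up, but they do not show why this happens or how the change would behave on any other core.

As far as these compounds go, it remains open whether a fluoro or bromo group in place of the chloro would follow the same course with and without the cyano group. From the compounds shown here alone, it is also open whether a methoxy or trifluoromethyl group in place of the cyano would weaken the effect of chloro in place of methyl in the same way.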